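The compounds below may be only part of what the source reports. "The series", "measured", "known", "first", "only" and "open" are said of these compounds alone.

Measured so far in an ADME assay on BJ cells (Homo sapiens) for cytotoxicity, with a stated time of 72 h; on this read-out higher numbers stand for an effect only at larger amounts of compound and lower numbers for an effect already at smaller amounts:
compound 1, `C#Cc1ccccc1-c1c(C#N)c(-c2ccc(CC)cc2)nc2c1c(C)nn2-c1ccccc1`: > 20000 nM
compound 2, `Cc1ccccc1-c1nc2c(c(C)nn2-c2ccccc2)c(-c2ccccc2O)c1C#N`: 21000 nM

The reading for compound 1 is a limit of this assay, not a number: > 20000 nM. That puts one of the two values shown at the limit of > 20000 nM in this assay, at which 1 of the 2 values shown sits. Within the data shown here, compound 2 is therefore the only compound in the set with a measured number in this assay, and it gives 21000 nM. Among the measured compounds shown here, with no pair of measured compounds differing in one place, no step can be read off.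

Compound 3, `Cc1nn(-c2ccccc2)c2nc(-c3ccc4c(c3)CCCC4)c(C#N)c(-c3ccccc3O)c12`, is not yet measured. It differs from compound 2 by 1,2,3,4-tetrahydronaphthalen-6-yl in place of 2-methylphenyl on an aromatic carbon, the rest of the shared core being kept. For the move to compound 3 in this assay the expectation is a step of no more than the usual scatter, if anything toward an effect at smaller amounts. Compound 3 is accordingly expected at about 15000 nM, within 5000 nM to 40000 nM, which corresponds to an expected step of a 1.4-fold lower number from compound 2 to compound 3 (0.15 log units; within the scatter). Given both measured values, a result reported only as a limit is also plausible for compound 3.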

Compound 3, half-maximal effective concentration: > 20000 nM
Compound 3 was reported as a limit; the forecaster's own chance of this, stated with the estimate: 40%; at least 1.3-fold (0.12 log units) between middle value and limit.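

In this assay compound 3 gives > 20000 nM, which is a limit of the assay and not a number. Among these compounds, no step from compound 2 to compound 3 can be read. The compounds shown leave open how far 1,2,3,4-tetrahydronaphthalen-6-yl in place of 2-methylphenyl moves the read-out in this assay, or whether it moves it at all.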